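A few compounds are considered here, and "the series" means these few. Any claim that something is new, unique, unknown or untested is made for them only; others in the source may bear on it.

Measured so far in a functional assay on HepG2 cells (Homo sapiens) for cytotoxicity, read by MTT assay, with a stated time of 72 h; a higher number here means a weaker inhibitor, a lower number a stronger inhibitor:

- compound 1 `Cc1ccccc1Nc1nc2cccnc2[se]1` gives 507000 nM
- compound 2 `Cc1cccc(Nc2nc3cccnc3[se]2)c1` gives 56700 nM

Compound 2 holds the lower of the two numbers in this assay; the gap to compound 1 is beyond the usual scatter of repeated measurements. Both carry the same core, and the two differ only in where the single methyl sits on the aryl ring of the amine.

Compound 3 `Cc1ccc(Nc2nc3cccnc3[se]2)cc1C` has not been measured. Compared with compound 2 the change is methyl in place of hydrogen on an aromatic carbon. Going by the values given here, no step of this kind has been measured, so there is no direct precedent for its size. With the methyl of compound 2 kept in place and a second one added, no step beyond the scatter in this assay is expected in either direction; the estimated step from compound 2 to compound 3 is a 1.4-fold lower number from compound 2 to compound 3 (0.15 log units; within the scatter). For compound 3 the expected value in this assay is 40000 nM, with a range from 10000 nM to 160000 nM.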

Compound 3, half-maximal inhibitory concentration: 145000 nM
For compound 3 the middle estimate is 3.6-fold (0.56 log units) below the measured one, and the stated range covers the measured number.
By their numbers in this assay, from the lowest: compound 2; then compound 3; then compound 1.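

In this assay, methyl in place of hydrogen on an aromatic carbon, ortho to a methyl group and para to a large group, gives a 2.6-fold higher number from compound 2 to compound 3 (0.41 log units; beyond the scatter) as the only measured step of this kind in the series. The step is modest but beyond the scatter, and its direction shows that adding this methyl to compound 2 does not give a lower number. Nothing measured here bears on the origin of this step.

Going by these compounds, this reading rests on one pair, so it remains open whether the same step would hold on an aryl ring without the methyl of compound 2. Also open, on these data alone, is how a chlorine atom, a methoxy group or a carboxylic acid would compare with methyl at this position.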